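One chloro added to a compound at the limit

The source may hold more compounds than are shown below. What is called first, only, known or untested is meant among the compounds shown, and "the series" means these compounds.

In a functional assay on U-251 cells (Homo sapiens) (a higher number here means a weaker inhibitor of growth, a lower number a stronger inhibitor of growth), compound 1 `O=S(=O)(/C=C/c1ccc(F)cc1)Cc1ccc(Nc2ncnc3ccccc23)cc1` gives 10 nM. Compound 2 `O=S(=O)(/C=C/c1ccc(F)cc1F)Cc1ccc(Nc2ncnc3ccccc23)cc1` gives > 100000 nM, which is a limit of the assay and not a number. Compound 3 `O=S(=O)(/C=C/c1ccc(F)cc1F)Cc1ccc(Nc2ncnc3cc(Cl)ccc23)cc1` differs from compound 2 by one change: chloro in place of hydrogen on an aromatic carbon. Within the data shown here, the only measured step, an at least 10000-fold higher number from compound 1 to compound 2 (4.00 log units; beyond the scatter), is large and shows that swapping one hydrogen can shift this number far. That step involved fluoro rather than chloro, so it gives only a loose guide to size. A lower number is expected if any change can be read at all. Compound 3 is estimated at 20000 nM, within an expected range of 300 nM to 100000 nM. This estimate means an expected at least 5.0-fold lower number from compound 2 to compound 3 (0.69 log units; beyond the scatter).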

Compound 3, concentration for 50% growth inhibition: > 100000 nM
Compound 3: a limit, no number (the forecaster's own chance of this, stated with the estimate: 55%); middle value at least 5.0-fold (0.69 log units) away from the limit.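

No step from compound 2 to compound 3 can be read, because both values are limits and not numbers: the limit of > 100000 nM in this assay, at which 2 of the 3 values shown sit.

The compounds shown leave open whether chloro in place of hydrogen changes growth inhibition at all.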